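Swapping a Methoxypropyl Tail for a Nitro-Bearing Branch

This account rests on a few compounds, and the source may have more. Where it says the series, first, only, none or still open, it means among the compounds named here.

Of the compounds shown here, three built on one shared core have been measured in a physicochemical assay for lipophilicity; a higher number here means a more lipophilic compound, a lower number a more polar compound. Compound 1 `COC(C)CCOCn1cc[n+](C)c1/C=N/O` gives -2.22 in this assay, the highest of the three numbers shown, though only its gap to compound 2 lies beyond the scatter. Compound 3 `C[n+]1ccn(CCOCCCl)c1/C=N/O` gives -2.32, which sits within the scatter of compound 1, so these two cannot be told apart. Compound 2 `C[n+]1ccn(CCCCC#N)c1/C=N/O` gives -2.8. Going by the values given here, the one step measured between neighbours, a number 0.48 log units higher from compound 2 to compound 3 (beyond the scatter), shows that exchanging one chain end for another can shift the number by a modest but real amount.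

Compound 4 `C[n+]1ccn(COCC(C)(C)[N+](=O)[O-])c1/C=N/O` is not yet measured. It differs from compound 1 by 1-methyl-1-nitroethyl in place of 2-methoxypropyl on a saturated chain carbon bound to an oxygen on a saturated carbon. Among the compounds with values here, no measured step involves a 1-methyl-1-nitroethyl group, so the step from compound 2 to compound 3 is only a rough guide to how far such an exchange might reach. The change is therefore expected to move the number little, if anything slightly downward, with a number 0.18 log units lower from compound 1 to compound 4 (within the scatter). Compound 4 is estimated at -2.4, within a range from -2.9 to -1.9.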

Compound 4, distribution coefficient: -1.96
Compound 4: middle estimate off by 0.44 log units, on the low side; the measured number falls inside the stated range.
By their numbers in this assay, from the lowest: compound 2; then compounds 3, 1 and 4 (each within the scatter of the next, the first and the last beyond it).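

In this assay, exchanging the 2-methoxypropyl group for 1-methyl-1-nitroethyl gives a number 0.26 log units higher from compound 1 to compound 4 (within the scatter) and so leaves the two compounds indistinguishable. No other step shown touches this place, and this one shows that a group of 6 heavy atoms with 2 hydrogen-bond acceptors can replace one of 5 heavy atoms with 1 acceptor without a reading beyond the scatter. No supporting data are available to explain this result.

A single exchange cannot show whether the same holds for other groups at this place. An amine, a carboxylic acid or a longer chain in place of 1-methyl-1-nitroethyl would test whether the number stays put when the incoming group differs more from 2-methoxypropyl.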